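A few compounds are considered here, and "the series" means these few. Any claim that something is new, unique, unknown or untested is made for them only; others in the source may bear on it.

Compound 1, with the structure `CCCCc1nc(=O)c(S(=O)(=O)c2ccc(-c3ccc(F)cc3)cc2)c(O)n1-c1c(OC)cccc1OC`, was tested in an ADME assay for permeability, using PAMPA, at pH 5.5; a higher number here means that the compound crosses the layer faster, a lower number that the compound crosses the layer more slowly. In this assay compound 1 gives 418 nm/s. Of the two compounds with a number in this assay, compound 1 has the higher one. Compound 3, with the structure `CCCCc1[nH]c(=O)c(S(=O)(=O)c2ccc(-n3ccccc3=O)cc2)c(O)c1-c1c(OC)cccc1OC`, gives 177 nm/s in this assay, a lower value than that of compound 1 by a margin beyond the usual scatter. Compound 2, with the structure `CCCCc1[nH]c(=O)c(S(=O)(=O)c2ccc(-c3ccc(F)nc3)cc2)c(O)c1-c1c(OC)cccc1OC`, shows "not determined" (no result reported) in this assay, so it carries no number there. Compound 4 has the structure `CCCCc1nc(=O)c(S(=O)(=O)c2ccc(C)cc2)c(O)n1-c1c(OC)cccc1OC` and has not yet been measured in this assay. Set against compound 1, its change is methyl in place of 4-fluorophenyl on an aromatic carbon: a methyl group replaces the 4-fluorophenyl group on an aromatic carbon of a six-membered aromatic ring of carbon only, para to a large group. For the measured compounds named here, no measured pair in this set shows what such a swap does in this assay, so the size of the step rests on expectation alone. The expected step is a 1.4-fold lower number from compound 1 to compound 4 (0.14 log units; within the scatter), small and downward if anything, and probably not beyond the scatter. Compound 4 is estimated at 300 nm/s in this assay, with a range from 150 nm/s to 600 nm/s.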

Compound 4, apparent permeability: 243 nm/s
Compound 4: middle estimate off by 1.2-fold (0.09 log units), on the high side, and the stated range covers the measured number.
By their numbers in this assay, from the lowest: compounds 3, 4 and 1 (each within the scatter of the next, the first and the last beyond it).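

For the compounds shown here, compound 4 gives the first pair in this set that differs in only one place, so the position can now be read directly: in this assay, replacing 4-fluorophenyl with methyl on an aromatic carbon, para to a large group, gives a 1.7-fold lower number from compound 1 to compound 4 (0.24 log units; within the scatter) and does not separate the two compounds. A single pair therefore shows that, in this assay and on the core of compound 1, the whole 4-fluorophenyl group can give way to one methyl without a step that can be told apart from the differences seen between repeated measurements. The data offer no measured property that could explain the size of this step or tie it to either group.

On these data alone, both groups at this position are free of hydrogen-bond donors, hydrogen-bond acceptors and charge, so it remains open how this assay would respond to an amine, a carboxylic acid or a longer chain at the same place. As far as these compounds go, it also remains open whether the same swap would give a similar step on a different core, since one pair cannot show that.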